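A few compounds are considered here, and "the series" means these few. Any claim that something is new, unique, unknown or untested is made for them only; others in the source may bear on it.

In an ADME assay on microsomes from liver (Mus musculus) for metabolic stability, read by HPLC, with a stated time of 4 h (on this read-out higher numbers stand for a longer-lived compound and lower numbers for a shorter-lived compound), compound 1 `CN(C)c1ccc2cc(-c3ccccc3Cl)c(N)nc2c1` gives 0.13 h and compound 2 `CN(C)c1ccc2cc(-c3nc(-c4ccccc4)cs3)c(N)nc2c1` gives 0.31 h. Compound 3 `CNc1ccc2cc(-c3cn(C)c4ccccc34)c(N)nc2c1` gives 1.3 h, the highest of the three numbers and beyond the scatter from both others. Compound 4 `Cn1cc(-c2cc3ccc(N4CCCCC4)cc3nc2N)c2ccccc21` carries piperidin-1-yl in place of methylamino on an aromatic carbon. For the measured compounds named here, no measured pair isolates a change at this place, so the expectation is loose. It rests on compound 1 at 0.13 h and compound 2 at 0.31 h, which also have no methylamino there, although both differ elsewhere too. A fall beyond the scatter is expected, with an estimated step of a 2.6-fold lower number from compound 3 to compound 4 (0.41 log units; beyond the scatter). Compound 4 is expected at 0.5 h, within an estimated range of 0.15 h to 1.4 h.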

Compound 4, half-life: 0.8 h
The estimate for compound 4 lay 1.6-fold (0.20 log units) below the measured number; the measured number falls inside the stated range.
By their numbers in this assay, from the lowest: compound 1; then compound 2; then compounds 4 and 3 (each within the scatter of the next).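

In this assay, piperidin-1-yl in place of methylamino on an aromatic carbon gives a 1.6-fold lower number from compound 3 to compound 4 (0.21 log units; within the scatter), the first step readable at this position. The larger group brings a six-membered non-aromatic ring and removes a hydrogen-bond donor, yet the two compounds cannot be told apart on this read-out. Nothing available explains this result. Still open, as far as these compounds go, is whether morpholin-4-yl or a primary amine at this place would also stay within the scatter of compound 3. Also open, from the compounds shown here alone, is how dimethylamino, carried by compound 1 and compound 2, would read on the core of compound 3.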